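This account rests on a few compounds, and the source may have more. Where it says the series, first, only, none or still open, it means among the compounds named here.

Compound 1, `O=C(Nc1cccc(-n2cc(-c3ccncc3)c(-c3ccc(Cl)c(O)c3)n2)c1)Nc1cccc(C(F)(F)F)c1`, gives in a functional assay on CCRF-CEM cells (Homo sapiens) for inhibition, read by sulforhodamine B assay, with a stated time of 48 h (a higher number here means that more compound is tolerated, a lower number that less compound is tolerated), only a limit, > 32500 nM.
Compound 2, `O=C(Nc1cccc(-n2cc(-c3ccncc3)c(-c3ccc(Cl)c(O)c3)n2)c1)Nc1ccc(Cl)c(Cl)c1`, gives in this assay only a limit, > 32500 nM.
Compound 3, `COc1cc(-c2nn(-c3cccc(NC(=O)Nc4cccc(C(F)(F)F)c4)c3)cc2-c2ccncc2)ccc1Cl`, gives in this assay only a limit, > 50000 nM.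

Compound 1 therefore stands at a limit, not at a number; the limit of > 32500 nM in this assay, at which 2 of the 3 values shown sit, and the limit of > 50000 nM in this assay, at which 1 of the 3 values shown sits, show that every value here is of that kind. Compound 4, `O=C(Nc1cccc(-n2cc(-c3ccncc3)c(-c3ccc(Cl)c(O)c3)n2)c1)Nc1cc(C(F)(F)F)cc(C(F)(F)F)c1`, differs from compound 1 by trifluoromethyl in place of hydrogen on an aromatic carbon. The two measured steps that bear on this, a step that the two limits leave unreadable from compound 1 to compound 2 and a step that the two limits leave unreadable from compound 1 to compound 3, are both unreadable, so no size or direction can be drawn from them for this assay. Compound 4 is expected to stay at the same limit, estimated at 40000 nM with a range of 20000 nM to 100000 nM. The expected step is a step that the limit leaves unreadable from compound 1 to compound 4.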

Compound 4, concentration lethal to 50% of the cells: > 50000 nM
Compound 4: only a limit was reported; the forecaster's own chance of this, stated with the estimate: 75%; middle value at least 1.2-fold (0.09 log units) away from the limit.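

For the compounds shown here, compound 1 and compound 4 are both reported only as limits, and no step between them can be read. The compounds shown leave open whether trifluoromethyl in place of hydrogen changes anything in this assay, and at what concentration any of them becomes lethal.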